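Removing the Anilide Fluorine: From Compound 2 to Compound 4

A few compounds are considered here, and "the series" means these few. Any claim that something is new, unique, unknown or untested is made for them only; others in the source may bear on it.

Compound 1 `Cc1c(C(=O)Nc2ccc(Oc3ccnc4[nH]ccc34)c(F)c2)nnn1-c1ccccc1` gives 290 nM in a functional assay on HT-29 cells (Homo sapiens) for cytotoxicity, read by MTT assay, with a stated time of 72 h; a lower number here means a stronger inhibitor, a higher number a weaker inhibitor.
Compound 2 `Cc1c(C(=O)Nc2ccc(Oc3ccnc4[nH]ccc34)c(F)c2)nnn1-c1ccc(F)cc1` gives 120 nM in this assay.
Compound 3 `COc1ccc(-n2nnc(C(=O)Nc3ccc(Oc4ccnc5[nH]ccc45)c(F)c3)c2C)cc1` gives 590 nM in this assay.

Compound 2 stands lowest of the three numbers in this assay. The step of a 2.4-fold lower number from compound 1 to compound 2 (0.38 log units; beyond the scatter) and the step of a 4.9-fold higher number from compound 2 to compound 3 (0.69 log units; beyond the scatter) both run beyond the scatter, so compound 2 is the strongest inhibitor measured so far. Compound 4 `Cc1c(C(=O)Nc2ccc(Oc3ccnc4[nH]ccc34)cc2)nnn1-c1ccc(F)cc1` differs from compound 2 by hydrogen in place of fluoro on an aromatic carbon. For the measured compounds named here, none of the measured steps, a 2.4-fold lower number from compound 1 to compound 2 (0.38 log units; beyond the scatter), a 2.0-fold higher number from compound 1 to compound 3 (0.31 log units; beyond the scatter) or a 4.9-fold higher number from compound 2 to compound 3 (0.69 log units; beyond the scatter), touches this part of the shared core; all three alter a different place. Going by the values given here, with no directly comparable step, only a modest change is expected, likely a somewhat higher number. Compound 4 is therefore expected to give 220 nM, with a range from 80 nM to 600 nM. The expected step is a 1.8-fold higher number from compound 2 to compound 4 (0.26 log units; within the scatter).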

Compound 4, half-maximal inhibitory concentration: 180 nM
The estimate for compound 4 lay 1.2-fold (0.09 log units) above the measured number; measured number inside the range.
By their numbers in this assay, from the lowest: compounds 2, 4 and 1 (each within the scatter of the next, the first and the last beyond it); then compound 3.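

In this assay, putting hydrogen in place of fluoro on this aromatic carbon, ortho to a large group and meta to a large group, gives a 1.5-fold higher number from compound 2 to compound 4 (0.18 log units; within the scatter), so compound 2 and compound 4 cannot be told apart. At this position, then, the fluoro is not needed to keep a number of this size. No measurement shown here explains this result.

Still open, on these data alone, is what a chloro, methyl or amino group would do on this carbon. Also open, as far as these compounds go, is whether removing the fluoro from compound 3, which carries methoxy, would give an equally small step.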